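Swapping 3,4,5-trifluorophenyl for 3-(trifluoromethyl)phenyl

The source may hold more compounds than are shown below. What is called first, only, known or untested is meant among the compounds shown, and "the series" means these compounds.

Of the compounds shown here, three sharing one core have been measured in a functional assay on A-375 cells (Homo sapiens) for activation, with a stated time of 3 days; a higher number here means that more compound is needed for the effect, a lower number that less compound is needed. There, compound 1 (`O=C(Nc1ccc(-c2cscn2)cc1)C1CCCN(Cc2ccc(F)c(F)c2)C1`) gives 1240 nM, compound 2 (`O=C(Nc1ccc(-c2cscn2)cc1)C1CCCN(Cc2cc(F)cc(F)c2)C1`) gives 1500 nM, and compound 3 (`O=C(Nc1ccc(-c2cscn2)cc1)C1CCCN(Cc2cc(F)c(F)c(F)c2)C1`) gives 1260 nM. Compound 3 thus stands within the scatter of both of the others, and the three numbers cannot be ranked.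

The next compound, compound 4 (`O=C(Nc1ccc(-c2cscn2)cc1)C1CCCN(Cc2cccc(C(F)(F)F)c2)C1`), has 3-(trifluoromethyl)phenyl in place of 3,4,5-trifluorophenyl on a saturated chain carbon bound to an amine nitrogen in a ring. Going by the values given here, three measured steps bear on this change. Replacing 3,4-difluorophenyl with 3,5-difluorophenyl gives a 1.2-fold higher number from compound 1 to compound 2 (0.08 log units; within the scatter). Putting fluoro in place of hydrogen on an aromatic carbon gives a 1.0-fold higher number from compound 1 to compound 3 (0.01 log units; within the scatter) and a 1.2-fold lower number from compound 2 to compound 3 (0.08 log units; within the scatter). All three are small and lie within the scatter, but none of them involves a trifluoromethyl group, so they guide the expectation without testing it directly. No shift beyond the scatter is therefore expected, and the estimated step is a 1.0-fold higher number from compound 3 to compound 4 (0.01 log units; within the scatter). For compound 4, the expected value in this assay is 1300 nM, with an estimated range from 600 nM to 2800 nM.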

Compound 4, half-maximal effective concentration: > 20000 nM
Compound 4: only a limit was reported; the forecaster's own chance of this, stated with the estimate: 5%; middle value at least 15-fold (1.18 log units) from the limit.
By their numbers in this assay, from the lowest: compounds 1, 3 and 2 (each within the scatter of the next). At a limit, above all of these: compound 4.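

In this assay compound 4 gives > 20000 nM, which is a limit of the assay and not a number. The earlier compounds shown here showed only that moving or adding fluoro on the phenyl ring at this position, on a saturated chain carbon bound to an amine nitrogen in a ring, left the numbers within the scatter, whereas the trifluoromethyl group gives an at least 15-fold higher number from compound 3 to compound 4 (1.20 log units; beyond the scatter), an at least 13-fold higher number from compound 2 to compound 4 (1.12 log units; beyond the scatter) and an at least 16-fold higher number from compound 1 to compound 4 (1.20 log units; beyond the scatter), so this position is not indifferent to every change of its substituents. The groups in compound 3 and compound 4 both hold three fluorine atoms and differ by one carbon, so the fluorine count alone does not track the result, and the full size of the steps cannot be read, as they rest on a single value at the limit: the limit of > 20000 nM in this assay, at which 1 of the 4 values shown sits.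

Going by these compounds, what stays open is whether the trifluoromethyl group itself goes with this large step or whether its placement on the ring does. How a chloro, methyl or methoxy group on that phenyl ring would read in this assay also remains unknown from the compounds shown.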